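The source may hold more compounds than are shown below. What is called first, only, known or untested is meant among the compounds shown, and "the series" means these compounds.

Measured so far in a functional assay on A549 cells (Homo sapiens) for cytotoxicity, read by MTT assay; on this read-out higher numbers stand for weaker inhibition and lower numbers for stronger inhibition:
Compound 1 `COc1ccc(OC)c(C(=O)/C=C/c2ccco2)c1`: 27900 nM
Compound 2 `COc1ccc(OC)c(C(=O)/C=C/c2ccc(C)o2)c1`: 51500 nM

Compound 2 stands within the usual scatter of compound 1, so these two compounds cannot be ranked. The next compound, compound 3 `COc1ccc(OC)c(C(=O)/C=C/c2occc2Br)c1`, has not yet been measured. The structural change from compound 2 is 3-bromofuran-2-yl in place of 5-methylfuran-2-yl on a double-bonded chain carbon bound to a double-bonded chain carbon. Here, 3-bromofuran-2-yl takes the place of 5-methylfuran-2-yl on a double-bonded chain carbon bound to a double-bonded chain carbon, and the rest of the molecule stays the same.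

Going by the values given here, only one measured step bears on this change: methyl in place of hydrogen on an aromatic carbon, which gave a 1.8-fold higher number from compound 1 to compound 2 (0.27 log units; within the scatter). Among the compounds with values here, no compound carrying bromine has been measured, so this single small step offers only weak guidance. In this assay, no step beyond the scatter is therefore expected, and the direction remains uncertain. The estimated step is a 1.5-fold lower number from compound 2 to compound 3 (0.17 log units; within the scatter). Compound 3 is expected at about 35000 nM, with an estimated range from 14000 nM to 80000 nM.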

Compound 3, half-maximal inhibitory concentration: 14900 nM
Compound 3: middle estimate off by 2.3-fold (0.37 log units), on the high side, within the range that was stated.
By their numbers in this assay, from the lowest: compounds 3, 1 and 2 (each within the scatter of the next, the first and the last beyond it).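

Going by these compounds alone, this is the first step in this assay to clear the usual scatter: 3-bromofuran-2-yl in place of 5-methylfuran-2-yl on a double-bonded chain carbon bound to a double-bonded chain carbon gives a 3.5-fold lower number from compound 2 to compound 3 (0.54 log units; beyond the scatter), which points towards stronger inhibition and shows that the group at this place can shift the read-out by a measurable amount. The other comparison is more cautious, as putting a bromine on the unsubstituted furan gives a 1.9-fold lower number from compound 1 to compound 3 (0.27 log units; within the scatter), so bromine cannot be credited with a real gain over the plain furan of the first compound, and the clear step holds only against the methyl compound. Nothing measured here explains why the swap from methyl-bearing to bromine-bearing furan moves the read-out.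

The three compounds leave open whether the step depends on the bromine itself or on losing the methyl, since that swap alters both at once. They also leave open how a chloro group, a methoxy group, an amine or a carboxylic acid on the furan would behave at this same place.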